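Cytotoxicity notes: the step from compound 3 to compound 4

A few compounds are considered here, and "the series" means these few. Any claim that something is new, unique, unknown or untested is made for them only; others in the source may bear on it.

In an ADME assay on HEK-293T cells (Homo sapiens) for cytotoxicity, with a stated time of 48 h (on this read-out higher numbers stand for lower toxicity in this test and lower numbers for higher toxicity in this test), compound 1 `CCc1ncnc(NC(C)c2ccc3c(c2)NCCO3)c1Cl` returns a limit rather than a number, > 10000 nM. Compound 2 `CCC(Nc1cc(C)ncn1)c1ccc(Oc2ccc(F)cc2)cc1` likewise sits at a limit in this assay, > 10000 nM. Compound 3 `CCC(Nc1cc(COC)ncn1)c1ccc(Oc2ccc(F)cc2)cc1` also reaches only a limit in this assay, > 10000 nM. Within the data shown here, the single step between measured neighbours, methoxy in place of hydrogen on a saturated chain carbon bound to an aromatic carbon, is a step that the two limits leave unreadable from compound 2 to compound 3. Compound 3 therefore stands where every measured value stands, at the limit of > 10000 nM in this assay, at which 3 of the 3 values shown sit, and nothing in the numbers separates it from compound 1 or compound 2.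

Compound 4 `CCC(Nc1nc(C)nc(Cl)c1N)c1ccc(Oc2ccc(F)cc2)cc1` differs from compound 3 by 5-amino-6-chloro-2-methylpyrimidin-4-yl in place of 6-(methoxymethyl)pyrimidin-4-yl on an amine nitrogen, in words 5-amino-6-chloro-2-methylpyrimidin-4-yl in place of 6-(methoxymethyl)pyrimidin-4-yl on an amine nitrogen. Among the measured compounds shown here, no measured step bears on this change; the only step, from compound 2 to compound 3, cannot be read. The expected step, as an estimate, is a number no higher from compound 3 to compound 4 (the limit leaves the size open), none beyond the scatter. Compound 4 is accordingly expected to give about 10000 nM in this assay, most probably again as a limit, within a range of 5000 nM to 20000 nM.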

Compound 4, half-maximal cytotoxic concentration: > 10000 nM
Compound 4 ended at the assay's limit (the forecaster's own chance of this, stated with the estimate: 80%); the middle value lies on the limit itself.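

In this assay compound 4 gives > 10000 nM, a limit and not a number. The steps to compound 4 from compound 2 and from compound 3 therefore cannot be read, and the series stands together: the limit of > 10000 nM in this assay, at which 4 of the 4 values shown sit.

The compounds shown leave open where any of the four truly lies beyond that limit, and so how large any change in the series is.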